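The source may report more compounds than this note shows. Statements on the series, on what has been measured and on what is new or still open speak of the compounds shown alone.

Measured so far:
compound 1 `CC1(C)C(=O)N(c2ccc([N+](=O)[O-])c(C(F)(F)F)c2)C(=S)N1c1cccc(S(F)(F)(F)(F)F)c1`, which in a functional assay on LNCaP cells (Homo sapiens) for antiproliferative activity, read by propidium iodide staining, with a stated time of 96 h (a lower number here means a stronger inhibitor, a higher number a weaker inhibitor), gives 100000 nM;
compound 2 `CC1(C)C(=O)N(c2ccc(C#N)c(C(F)(F)F)c2)C(=S)N1c1cccc(S(F)(F)(F)(F)F)c1`, which in this assay gives 6900 nM;
compound 3 `CC1(C)C(=O)N(c2ccc(C#N)cc2C(F)(F)F)C(=S)N1c1ccc(S(F)(F)(F)(F)F)cc1`, which in this assay gives 3000 nM.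

Compound 3 stands lowest of the three, with compound 2 nearest and compound 1 furthest, both gaps beyond the scatter. Compound 2 and compound 3 share the same atoms joined differently; the difference between the two cores is not broken down here.

Within the core of compound 2, the change nitro in place of cyano on an aromatic carbon produced a 14-fold higher number from compound 2 to compound 1 (1.16 log units; beyond the scatter), a large loss.

Compound 4 `CC1(C)C(=O)N(c2ccc([N+](=O)[O-])cc2C(F)(F)F)C(=S)N1c1ccc(S(F)(F)(F)(F)F)cc1` carries the same kind of change on the core of compound 3: nitro in place of cyano on an aromatic carbon. The surroundings differ: in the earlier pair the altered carbon is ortho to a trifluoromethyl group, here it is meta to a trifluoromethyl group, in both cases para to a large group.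

Going by the values given here, from compound 3 to compound 4 a step of about a 10-fold higher number from compound 3 to compound 4 (1.00 log units; beyond the scatter) is expected, resting on the single precedent a 14-fold higher number from compound 2 to compound 1 (1.16 log units; beyond the scatter) and tempered for the changed surroundings. Compound 4 is therefore estimated at 30000 nM, within 9000 nM to 100000 nM.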

Compound 4, half-maximal inhibitory concentration: 100000 nM
Estimate against measurement, compound 4: 3.3-fold (0.52 log units) below; low and high end bracket the measured number.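

Nitro in place of cyano on an aromatic carbon again gives in this assay a 33-fold higher number from compound 3 to compound 4 (1.52 log units; beyond the scatter), a large loss. The step therefore carries over between the two cores in direction, and its size does not separate them: the same change on two cores in this assay, a 14-fold higher number (1.16 log units; beyond the scatter) from compound 2 to compound 1 and a 33-fold higher number (1.52 log units; beyond the scatter) from compound 3 to compound 4, 2.3-fold (0.36 log units) apart, within the scatter of two such steps. Going by these compounds alone, this rests on only two pairs, so it does not show that the step would hold on any other core, and it gives no reason why nitro falls so far behind cyano.

The compounds shown leave open how a carboxylic acid, a primary amide or a methyl sulfone would read in this assay on the same aromatic carbon, where only cyano and nitro appear here. Also open, from the compounds shown here alone, is whether the step keeps its size when the thiocarbonyl of the shared core gives way to a carbonyl.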